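A few compounds are considered here, and "the series" means these few. Any claim that something is new, unique, unknown or untested is made for them only; others in the source may bear on it.

Compound 1: `C=CC(C)(O)CC[C@@H]1C(=C)CC[C@H](Br)[C@@]1(C)CCC(O)C(C)(C)Cl` — in a functional assay on HepG2 cells (Homo sapiens) for cytotoxicity, read by MTT assay, with a stated time of 48 h (a lower number here means a stronger inhibitor, a higher number a weaker inhibitor), compound 1 gives 48700 nM.
Compound 2: `C=CC(C)(O)CC[C@@H]1C(=C)CC[C@H](Br)[C@@]1(C)CCC(OC)C(C)(C)O` — in this assay compound 2 gives > 100000 nM, a limit of the assay rather than a number.

Compound 2 thus stands only at a limit: the limit of > 100000 nM in this assay, at which 1 of the 2 values shown sits. For the measured compounds named here, the one measured step that bears on the present change is an at least 2.0-fold higher number from compound 1 to compound 2 (0.31 log units; beyond the scatter), and the new compound 3, `C=CC(C)(O)CC[C@@H]1C(=C)CC[C@H](Br)[C@@]1(C)CCC(O)C(=C)C`, is reached by the change (1-hydroxy-2-methylprop-2-en-1-yl in place of 2-hydroxy-1-methoxy-2-methylpropyl on a saturated chain carbon, two bonds along the chain from a saturated ring carbon). Since the hydroxyl here returns to the same chain carbon as in compound 1 while the methoxy is dropped, compound 3 is expected to sit nearer to compound 1 than to compound 2, though an unknown share of that step may be recovered. The step of an at least 1.4-fold lower number from compound 2 to compound 3 (0.15 log units; that floor lies within the scatter) is therefore expected to fall from the limit into measurable territory. Compound 3 is estimated in this assay at 70000 nM, within 25000 nM to 200000 nM.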

Compound 3, half-maximal inhibitory concentration: > 100000 nM
Compound 3 ended at the assay's limit; the forecaster's own chance of this, stated with the estimate: 40%; at least 1.4-fold (0.15 log units) between middle value and limit.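

With the hydroxyl on the same chain carbon in both compounds, putting 1-methylethenyl in place of 1-chloro-1-methylethyl gives an at least 2.0-fold higher number from compound 1 to compound 3 (0.31 log units; beyond the scatter) in this assay, so the free hydroxyl alone does not restore the measurable value of compound 1. As far as these compounds go, of the three compounds, only compound 1 carries the chlorine and only compound 1 reads as a number, while compound 2 and compound 3 both stand at a limit of the assay rather than at a number: the limit of > 100000 nM in this assay, at which 2 of the 3 values shown sit. The step between compound 2 and compound 3 therefore cannot be read, and whether the 2-hydroxy-1-methoxy-2-methylpropyl and 1-hydroxy-2-methylprop-2-en-1-yl groups differ at all stays unknown.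

From the compounds shown here alone, it remains open whether a bromine or an amine in place of the chlorine would keep a measurable value in this assay. Going by these compounds, the true values of compound 2 and compound 3 also remain unknown.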